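This account rests on a few compounds, and the source may have more. Where it says the series, first, only, none or still open, it means among the compounds named here.

Within the data shown here, compound 2 `N#CC1=C(N)Oc2c(c3nc4ccccc4nc3c3ccccc23)C12C(=O)N(Cc1cnnn1-c1cccc(S(N)(=O)=O)c1)c1ccccc12` is the only compound with a number in an ADME assay on HUVEC cells (Homo sapiens) for antiproliferative activity, read by MTT assay, with a stated time of 48 h; a higher number here means a weaker inhibitor, a lower number a stronger inhibitor: there compound 2 gives 38600 nM. Compound 1 `N#CC1=C(N)Oc2c(c3nc4ccccc4nc3c3ccccc23)C12C(=O)N(Cc1cnnn1-c1ccc(F)cc1)c1ccccc12` gives only a limit of the assay, > 50000 nM. Among the measured compounds shown here, the single measured step, an at least 1.2-fold lower number from compound 1 to compound 2 (0.11 log units; that floor lies within the scatter), bears on the change in hand, since compound 3 `N#CC1=C(N)Oc2c(c3nc4ccccc4nc3c3ccccc23)C12C(=O)N(Cc1cnnn1-c1ccc(F)c(Cl)c1)c1ccccc12` carries 3-chloro-4-fluorophenyl in place of 3-sulfamoylphenyl on an aromatic nitrogen. Because that step is bounded by the limit of > 50000 nM in this assay, at which 1 of the 2 values shown sits, its size cannot be set beyond the scatter, so the expected move for compound 3 is back toward the limit. Compound 3 is expected to give 50000 nM, between 25000 nM and 100000 nM. The expected step is a 1.3-fold higher number from compound 2 to compound 3 (0.11 log units; within the scatter).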

Compound 3, half-maximal inhibitory concentration: > 50000 nM
Compound 3 was reported as a limit; the forecaster's own chance of this, stated with the estimate: 55%; the middle value lies on the limit itself.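

Replacing 3-sulfamoylphenyl with 3-chloro-4-fluorophenyl on this aromatic nitrogen gives an at least 1.2-fold higher number from compound 2 to compound 3 (0.11 log units; that floor lies within the scatter). Thus, in this assay, this change also shows no separation from the sulfamoyl compound beyond the scatter, while compound 3 gives > 50000 nM, which is a limit of the assay and not a number. The step from compound 1 to compound 3 cannot be read, and the size of any effect at this position stays unset: the limit of > 50000 nM in this assay, at which 2 of the 3 values shown sit.

Still open, as far as these compounds go, is whether a carboxylic acid or an amine in place of the sulfamoyl group on this phenyl ring would give a number clearly apart from that of compound 2.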